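The source may report more compounds than this note shows. Statements on the series, on what has been measured and on what is new or still open speak of the compounds shown alone.

Measured compounds:
compound 1 `COc1ccc(Br)cc1-c1nc(N)nc(N)n1` — 49%
compound 2 `CS(=O)(=O)c1cccc(-c2nc(N)nc(N)n2)c1` — -6%
compound 3 `Nc1nc(N)nc(-c2ccc(F)cc2)n1` — 84%

In a functional assay on the whole organism with Rattus norvegicus as the target, at a dose of 20 mg/kg by the intraperitoneal route (on this read-out higher numbers stand for more inhibition at the one dose given (going by the name of the read-out) and lower numbers for less inhibition), compound 2 stands lowest of the three numbers shown: compound 1 lies above it by a gap beyond the scatter, and compound 3 lies further above by a gap also beyond the scatter. Compound 4 `Nc1nc(N)nc(-c2cccc(Cl)c2)n1` has not been measured in this assay. It differs from compound 2 in one place: chloro in place of methylsulfonyl on an aromatic carbon. Among the compounds with values here, no step between measured compounds matches this change, so the expectation rests on the spread of the three numbers. Since compound 3, which also carries a single halogen on the aromatic ring, gives 84%, a step upward beyond the scatter is expected, a number 61 percentage points higher from compound 2 to compound 4 (beyond the scatter). Compound 4 is estimated to give 55%, with a range from 15% to 90%.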

Compound 4, a percentage reported as inhibition, in the whole organism at one dose (the size of the read-out at that dose, not a potency): 100%
Compound 4: middle estimate off by 45 percentage points, on the low side; measured number outside the range, above it.
By their numbers in this assay, from the lowest: compound 2; then compound 1; then compound 3; then compound 4.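

In this assay, within the data shown here, chloro in place of methylsulfonyl on this aromatic carbon gives a number 106 percentage points higher from compound 2 to compound 4 (beyond the scatter) and is the only single-place comparison. The read-out is therefore highly sensitive to the group at this carbon, with a single chlorine atom replacing a group of four heavy atoms and two hydrogen-bond acceptors. Nothing at hand explains the step.

On these data alone, whether the step comes from losing methylsulfonyl or gaining chloro remains open. A methyl or an amine on the same carbon would help separate the two.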